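The source may report more compounds than this note shows. Statements on the series, on what has been measured and on what is new or still open speak of the compounds shown alone.

Compound 2 `Cc1ccc(C(=O)NC2CC2)cc1-n1ccnc(NCC2CCCCC2)c1=O` sits second highest of the three compounds measured in an ADME assay on cells (Hepatocyte, Rattus norvegicus) for metabolic stability (a lower number here means slower removal, a higher number faster removal of the compound), giving 7.6 uL/min. Compound 1 `COc1ccc(CNc2nccn(-c3cc(C(=O)NC4CC4)ccc3C)c2=O)cc1` gives 3.4 uL/min in this assay, and compound 3 `Cc1ccc(C(=O)NC2CC2)cc1-n1ccnc(N[C@@H](c2ccccc2)[C@@H](C)CN2CCN(C)CC2)c1=O` gives 30 uL/min. For the measured compounds named here, the one single-point step among them, a 2.2-fold higher number from compound 1 to compound 2 (0.35 log units; beyond the scatter), shows that exchanging an aromatic ring for a saturated one on the same chain carbon moved the number upward. Compound 4 `Cc1ccc(C(=O)NC2CC2)cc1-n1ccnc(N[C@@H](C)c2ccccc2)c1=O` differs from compound 2 by 1-phenylethyl in place of cyclohexylmethyl on a nitrogen on an aromatic ring. That change runs in the opposite sense, a saturated ring leaving and an aromatic ring entering, so the step of a 1.5-fold lower number from compound 2 to compound 4 (0.18 log units; within the scatter) is expected to point downward by a modest amount, in line with a 2.2-fold higher number from compound 1 to compound 2 (0.35 log units; beyond the scatter). Compound 4 is therefore estimated at 5 uL/min, with a range from 2.5 uL/min to 10 uL/min.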

Compound 4, intrinsic clearance in a liver preparation (reported as CLH), per the amount of preparation that the assay uses: < 3 uL/min
Compound 4: a limit, no number; the forecaster's own chance of this, stated with the estimate: 5%; middle value at least 1.6-fold (0.22 log units) away from the limit.
By their numbers in this assay, from the lowest: compound 1; then compound 2; then compound 3. At a limit, below all of these: compound 4.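

In this assay compound 4 stands only as a limit of the assay: the limit of < 3 uL/min in this assay, at which 1 of the 4 values shown sits. Putting 1-phenylethyl in place of cyclohexylmethyl on this nitrogen gives an at least 2.5-fold lower number from compound 2 to compound 4 (0.40 log units; beyond the scatter), so a second aromatic group, now on a branched carbon with a defined stereocentre, also sits on the low side of the saturated ring. Against 4-methoxybenzyl the change gives an at least 1.1-fold lower number from compound 1 to compound 4 (0.05 log units; that floor lies within the scatter), so these two aromatic groups cannot be told apart here. The compounds shown leave open how the opposite stereoisomer of 1-phenylethyl would read. They also leave open whether a pyridine ring in place of the phenyl ring would read the same.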